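This account rests on a few compounds, and the source may have more. Where it says the series, first, only, none or still open, it means among the compounds named here.

Measured compounds:
compound 1, `Nc1nc(N2CCCC2)sc1C(=O)/C=C/c1ccc([N+](=O)[O-])cc1`, 26.3 ug/mL in a functional assay on MCF7 cells (Homo sapiens) for antiproliferative activity, read by MTT assay, with a stated time of 48 h; on this read-out higher numbers stand for weaker inhibition and lower numbers for stronger inhibition
compound 2, `Nc1nc(N2CCCCC2)sc1C(=O)/C=C/c1ccc(Br)cc1`, 25.6 ug/mL in this assay

On these two numbers compound 2 and compound 1 give values within the usual scatter of each other, so neither can be ranked ahead of the other. Compound 3, `Nc1nc(N2CCCCC2)sc1C(=O)/C=C/c1ccc([N+](=O)[O-])cc1`, is not yet measured. It differs from compound 2 by nitro in place of bromo on an aromatic carbon. Going by the values given here, no measured pair shows this exact change; compound 1, which also carries nitro, gives 26.3 ug/mL, close to compound 2. The step of a 1.0-fold higher number from compound 2 to compound 3 (0.01 log units; within the scatter) is therefore expected to be none beyond the scatter. Compound 3 is estimated at 26 ug/mL, between 13 ug/mL and 52 ug/mL.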

Compound 3, half-maximal inhibitory concentration: 14.6 ug/mL
The estimate for compound 3 lay 1.8-fold (0.25 log units) above the measured number, within the range that was stated.
By their numbers in this assay, from the lowest: compounds 3, 2 and 1 (each within the scatter of the next).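

Bromo and nitro can now be compared directly on the same piperidin-1-yl compound. At this aromatic carbon, para to a large group, nitro in place of bromo gives in this assay a 1.8-fold lower number from compound 2 to compound 3 (0.24 log units; within the scatter) and so does not separate the two groups. With nitro kept, piperidin-1-yl in place of pyrrolidin-1-yl gives a 1.8-fold lower number from compound 1 to compound 3 (0.26 log units; within the scatter) and leaves those two rings unseparated as well. Nothing measured here offers an explanation for these numbers.

Going by these compounds, whether an amine or a carboxylic acid at that aromatic carbon would move the number beyond the scatter remains open. So does the effect of a morpholine ring in place of piperidin-1-yl.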